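This account rests on a few compounds, and the source may have more. Where it says the series, first, only, none or still open, it means among the compounds named here.

Measured compounds in a functional assay on SK-BR-3 cells (Homo sapiens) for inhibition, read by MTT assay; a lower number here means a stronger inhibitor of growth, a higher number a weaker inhibitor of growth:
compound 1 `CC1=C(/C=C/C(C)=C/C=C/C(C)=C\C(=O)Nc2ccc(F)cc2)C(C)(C)CCC1n1ccnc1` gives 25100 nM
compound 2 `CC1=C(/C=C/C(C)=C/C=C/C(C)=C\C(=O)NCc2ccc(O)cc2)C(C)(C)CC=C1c1cncnc1` gives 11500 nM
compound 3 `CC1=C(/C=C/C(C)=C/C=C/C(C)=C\C(=O)Nc2ccccc2)C(C)(C)CCC1n1ccnc1` gives 1730 nM

Compound 3 stands lowest of the three numbers in this assay; compound 2 is its nearest neighbour and compound 1 the furthest, both gaps beyond the scatter. Compound 4 `CC1=C(/C=C/C(C)=C/C=C/C(C)=C\C(=O)Nc2ccc(O)cc2)C(C)(C)CCC1n1ccnc1` is not yet measured. It differs from compound 3 in one place: hydroxy in place of hydrogen on an aromatic carbon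

For the measured compounds named here, only one measured step touches the same ring. Going a 15-fold lower number from compound 1 to compound 3 (1.16 log units; beyond the scatter) removed a fluoro from that ring and gave a large drop in the number. Going by the values given here, that step shows the aromatic ring of the anilide to be a place where a single substituent moves the number a long way, but fluoro and hydroxy are different groups and the data contain no hydroxy-for-hydrogen step on an anilide. Compound 2 carries a hydroxy on its aromatic ring, yet it differs from compound 3 in several other places, so its value alone cannot be read as the effect of the hydroxy.

On this basis a moderate rise in the number is expected for compound 4, with wide uncertainty, giving a 2.9-fold higher number from compound 3 to compound 4 (0.46 log units; beyond the scatter) as the estimated step. Compound 4 is estimated at 5000 nM, within 1200 nM to 20000 nM.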

Compound 4, concentration for 50% growth inhibition: 3890 nM
The estimate for compound 4 lay 1.3-fold (0.11 log units) above the measured number, within the range that was stated.
By their numbers in this assay, from the lowest: compound 3; then compound 4; then compound 2; then compound 1.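

In this assay, for the compounds shown here, the step of a 2.2-fold higher number from compound 3 to compound 4 (0.35 log units; beyond the scatter) gives the first direct reading of hydroxy in place of hydrogen on this aromatic carbon, para to a large group, and the step is modest but beyond the scatter. The step of a 6.5-fold lower number from compound 1 to compound 4 (0.81 log units; beyond the scatter) shows that the identity of the entering group matters at this carbon, as hydroxy and fluoro are separated by a gap beyond the scatter; among these three compounds, the unsubstituted phenyl of compound 3 keeps the lowest number, and both substituents raise it, fluoro much further than hydroxy. Nothing available explains this order of hydrogen, hydroxy and fluoro.

The compounds shown leave open where a methoxy, an amine or a carboxylic acid on the same carbon would fall relative to these three groups, and whether a hydroxy on another carbon of the ring would give a similar step. Also open, on these data alone, is whether the same change from hydrogen to hydroxy would give a step of similar size on the core of compound 2.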